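A few compounds are considered here, and "the series" means these few. Any claim that something is new, unique, unknown or untested is made for them only; others in the source may bear on it.

Working notes on the series. For the measured compounds named here, in a functional assay on MKN-45 cells (Homo sapiens) for inhibition, with a stated time of 72 h (on this read-out higher numbers stand for weaker inhibition and lower numbers for stronger inhibition), compound 1 (`COc1ccc(S(=O)(=O)N2CCc3cccc(-c4ccc(F)nc4)c32)cc1`) gives 145 nM and compound 2 (`COc1ccc(-c2cccc3c2N(S(=O)(=O)c2ccc(OC)cc2)CC3)cc1`) gives 211 nM, so compound 2 lies within the scatter of compound 1, the only other measured member. Compound 3 (`COc1ccc(S(=O)(=O)N2CCc3cccc(-c4ccncc4)c32)cc1`) differs from compound 2 as follows: pyridin-4-yl in place of 4-methoxyphenyl on an aromatic carbon. Going by the values given here, the one measured step on this aromatic carbon, a 1.5-fold higher number from compound 1 to compound 2 (0.16 log units; within the scatter), stayed within the scatter, so no step beyond the scatter is expected in this assay. The expected change is a 1.2-fold lower number from compound 2 to compound 3 (0.09 log units; within the scatter). For compound 3 the estimated value is 170 nM, with an expected range of 60 nM to 450 nM.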

Compound 3, half-maximal inhibitory concentration: 69.5 nM
Compound 3: middle estimate off by 2.4-fold (0.39 log units), on the high side; the measured number falls inside the stated range.
By their numbers in this assay, from the lowest: compound 3; then compounds 1 and 2 (each within the scatter of the next).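

On this aromatic carbon, a change of group now moves the number in this assay beyond the scatter: pyridin-4-yl gives a 3.0-fold lower number from compound 2 to compound 3 (0.48 log units; beyond the scatter) and a 2.1-fold lower number from compound 1 to compound 3 (0.32 log units; beyond the scatter), whereas the earlier step between the other two groups stayed within it. Compound 3 therefore stands apart from both other members, though both steps are modest. Nothing measured here gives a reason for these steps. Open, from the compounds shown here alone, is how an unfluorinated pyridin-3-yl would compare with compound 3 . Also open, going by these compounds, is how a morpholine or a carboxylic acid would read on this carbon.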